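The compounds below may be only part of what the source reports. "The series", "measured", "known", "first", "only" and "open" are said of these compounds alone.

Measured in a functional assay on A2780 cells (Homo sapiens) for antiproliferative activity, read by resazurin assay, with a stated time of 72 h; a higher number here means a weaker inhibitor, a lower number a stronger inhibitor:

Compound 1 `CN(Cc1ccccc1)C(=O)c1cc2c(Cc3ccccc3Cl)n[nH]c2cc1O`: "not determined" (no result reported)
Compound 2 `CN(Cc1ccccc1)C(=O)c1cc2c(Cc3cccc(F)c3)n[nH]c2cc1O`: 1700 nM
Compound 3 `Cc1cccc(Cc2n[nH]c3cc(O)c(C(=O)NCc4ccccc4)cc23)c1`: > 10000 nM, a limit

Compound 3 stands at > 10000 nM in this assay. That entry is a limit of the assay and not a number.

Compound 4 `Cc1cccc(Cc2n[nH]c3cc(O)c(C(=O)N(C)Cc4ccccc4)cc23)c1` is compound 3 with one small change: methyl in place of hydrogen on an amide-type nitrogen. In words, a methyl takes the place of hydrogen on an amide-type nitrogen. Going by the values given here, no pair of measured compounds differs in only one place, so the size of this step cannot be read directly from the data. The nearest guide is compound 2, which also has a methyl on its amide-type nitrogen and gives 1700 nM in this assay. Compound 1 has the same methyl but offers no help, since it has no result. Compound 2 is only a loose guide, as it is not otherwise identical to compound 4. Even so, its value points towards a lower number, meaning stronger inhibition, and the change is expected to go that way. The expected step of an at least 2.8-fold lower number from compound 3 to compound 4 (0.45 log units; beyond the scatter) is an estimate that carries real uncertainty, and a second limit remains possible. For compound 4 the estimated value is 3500 nM, with an expected range of 1000 nM to 10000 nM.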

Compound 4, half-maximal inhibitory concentration: 490 nM
The estimate for compound 4 lay 7.1-fold (0.85 log units) above the measured number, and the stated range ends above it.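

Going by these compounds alone, with a methyl in place of the hydrogen on the amide-type nitrogen, this assay shows an at least 20-fold lower number from compound 3 to compound 4 (1.30 log units; beyond the scatter), the first direct reading of a change at this position, and in this pair the methyl goes with much stronger inhibition. That step starts from a limit of the assay and not a number, the entry for compound 3: the limit of > 10000 nM in this assay, at which 1 of the 4 values shown sits.

With the methyl on the nitrogen kept, the group on the aromatic carbon also counts, since methyl in place of fluoro there gives a 3.5-fold lower number from compound 2 to compound 4 (0.54 log units; beyond the scatter).

The effect on the nitrogen rests on this single pair, so the compounds shown do not tell whether an ethyl or a longer chain in place of the methyl would carry the gain further, or whether the same step would appear with fluoro on the aromatic carbon. Within the data shown here, compound 1 has no result, so no step to it can be read, and the effect of an amine or a carboxylic acid on that aromatic carbon also stays open.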